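Chloro to Bromo on the Sulfonamide Aryl Ring

A few compounds are considered here, and "the series" means these few. Any claim that something is new, unique, unknown or untested is made for them only; others in the source may bear on it.

The series shares a methoxyphenylsulfonamide core attached to a pyridine. Compound 1 `COc1ccc(Cl)cc1S(=O)(=O)Nc1cncc(-c2cccnc2)c1` carries a pyridyl group on that pyridine; in an assay on isolated protein for inhibition of alkaline phosphatase, tissue-nonspecific isozyme (Homo sapiens) (on this read-out higher numbers stand for weaker inhibition and lower numbers for stronger inhibition), the outcome for compound 1 is "not determined" (no result reported). Compound 2 `CNC(=O)c1cncc(NS(=O)(=O)c2cc(Cl)ccc2OC)c1` has a methylated amide and gives only a limit of the assay, > 20000 nM, in this assay. Among the measured compounds shown here, compound 3 `COc1ccc(Cl)cc1S(=O)(=O)Nc1cncc(C(N)=O)c1`, with the unsubstituted amide, gives 105 nM in this assay and is the only compound with a single number among the three. For the measured compounds named here, the step of an at least 190-fold lower number from compound 2 to compound 3 (2.27 log units; beyond the scatter) is the sole measured step, and it concerns hydrogen in place of methyl on the amide nitrogen, with one end sitting at the limit (the limit of > 20000 nM in this assay, at which 1 of the 3 values shown sits).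

Compound 4 `COc1ccc(Br)cc1S(=O)(=O)Nc1cncc(C(N)=O)c1` differs from compound 3 in one place: bromo in place of chloro on an aromatic carbon, meta to a large group and para to a methoxy group. Going by the values given here, no measured step touches this halogen, so the amide step gives no direct guide, and the change is expected to stay within the scatter of this assay, giving the step of a 1.1-fold lower number from compound 3 to compound 4 (0.02 log units; within the scatter). Compound 4 is therefore estimated at 100 nM in this assay, with a range from 40 nM to 250 nM.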

Compound 4, half-maximal inhibitory concentration: 121 nM
For compound 4 the middle estimate is 1.2-fold (0.08 log units) below the measured one; the range from low to high includes it.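

In this assay, among the compounds shown here, the exchange of chloro for bromo gives a 1.2-fold higher number from compound 3 to compound 4 (0.06 log units; within the scatter) and so is the first measured change on this aromatic carbon, meta to a large group and para to a methoxy group. For the compounds shown here, the earlier compounds could not speak to this position: their only measured step, an at least 190-fold lower number from compound 2 to compound 3 (2.27 log units; beyond the scatter) on the amide nitrogen, lies elsewhere in the molecule and is large, while the halogen exchange cannot be told apart from the scatter. Compound 3 and compound 4 therefore show that, at this carbon, chloro and bromo read alike in this assay, although nothing given here bears on why they do.

The compounds shown leave open how this carbon would respond to a group other than these two halogens, such as fluoro, methyl, a nitrile or an amine. They also leave open whether a carboxylic acid or a longer chain in place of the unsubstituted amide would keep the inhibition seen with compound 3 and compound 4, and whether the amide step would look the same with bromo on the ring.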